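The source may report more compounds than this note shows. Statements on the series, on what has been measured and on what is new or still open speak of the compounds shown alone.

Measured compounds:
compound 1 `COc1ccc(S(=O)(=O)Nc2nn(C)c3cc(C)[nH]c(=O)c23)c(OC)c1`: -2%
compound 2 `Cc1cc2nc(N)nc(N)c2c(=O)[nH]1`: -4%

In an assay on isolated protein for inhibition of ribosomal protein S6 kinase alpha-1 (Homo sapiens), read by mobility shift assay, tested at 30 uM (on this read-out higher numbers stand for more inhibition at the one concentration tested (going by the name of the read-out) and lower numbers for less inhibition), compound 1 gives -2% and compound 2 gives -4%. The two numbers lie within the scatter of each other, so compound 2 is not set apart from compound 1; both show essentially no inhibition. Compound 3 `Cc1nc(N)c2c(=O)[nH]c(C)cc2n1` differs from compound 2 by methyl in place of amino on an aromatic carbon. Going by the values given here, no step between measured compounds is known, and with compound 2 at -4% the step of a number 1 percentage points higher from compound 2 to compound 3 (within the scatter) is expected to stay within the scatter, in no particular direction. Compound 3 is therefore estimated at -3%, with a range of -13% to 8%.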

Compound 3, a percentage reported as inhibition, at one concentration (the size of the read-out at that concentration, not a potency): -23%
Beside the measured number, compound 3's estimate is 20 percentage points above it, outside the stated range (below it).
By their numbers in this assay, from the lowest: compound 3; then compounds 2 and 1 (each within the scatter of the next).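

In this assay the aromatic carbon between two ring nitrogen atoms proves sensitive to its substituent: methyl in place of amino gives a number 19 percentage points lower from compound 2 to compound 3 (beyond the scatter) and so this change registers on the read-out. The step runs towards lower numbers, so this change brings no gain in inhibition at this position. Nothing at hand bears on why the number falls. From the compounds shown here alone, whether an ethylamine, a methoxy group or a longer chain at this position would raise the number remains open, as does whether the step would recur on another core.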